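The source may hold more compounds than are shown below. What is called first, only, known or untested is meant among the compounds shown, and "the series" means these compounds.

Measured compounds: compound 1 `COc1ccc(CCCOC(=O)N(c2ccccc2)C2CN3CCC2CC3)cc1`, which in an assay on CHO cells for displacement of a labelled ligand from muscarinic acetylcholine receptor M5 (Homo sapiens), read by scintillation counting, with a stated time of 2 h (a higher number here means a weaker inhibitor, a lower number a stronger inhibitor), gives 640 nM; compound 2 `O=C(OCCc1ccccc1)N(c1ccccc1)C1CN2CCC1CC2`, which in this assay gives 260 nM.

Going by the values given here, compound 2 holds the lowest of the two numbers in this assay, and the one measured step, a 2.5-fold lower number from compound 1 to compound 2 (0.39 log units; beyond the scatter), separates it from compound 1. Compound 3 `O=C(OCCCc1ccc(Cl)c(Cl)c1)N(c1ccccc1)C1CN2CCC1CC2` differs from compound 2 by 3,4-dichlorobenzyl in place of phenyl on a saturated chain carbon, two bonds along the chain from an oxygen next to a carbonyl group. On these data alone, this runs opposite to that step, back toward a benzyl-bearing chain as in compound 1, so a modest rise is expected, a 1.9-fold higher number from compound 2 to compound 3 (0.28 log units; within the scatter), though the chlorines are untested. Compound 3 is therefore estimated at 500 nM, within 180 nM to 1500 nM.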

Compound 3, inhibition constant: 130 nM
For compound 3 the middle estimate is 3.8-fold (0.59 log units) above the measured one, and the stated range ends above it.
By their numbers in this assay, from the lowest: compounds 3 and 2 (each within the scatter of the next); then compound 1.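

With the chain length held, the ring substituent matters at this position: 3,4-dichlorophenyl in place of 4-methoxyphenyl gives a 4.9-fold lower number from compound 1 to compound 3 (0.69 log units; beyond the scatter) in this assay. The longer 3,4-dichlorobenzyl in place of phenyl gives a 2.0-fold lower number from compound 2 to compound 3 (0.30 log units; within the scatter), so this larger group is tolerated on the chain carbon. No measurement shown here accounts for either step.

Open, on these data alone, is whether both chlorines are needed, or whether a single chlorine would give the same reading on this chain. Also open, as far as these compounds go, is how an amine or a carboxylic acid on the ring, or a longer chain, would read.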